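Adding a Methoxy Group to the Propyl Amide Analogue

A few compounds are considered here, and "the series" means these few. Any claim that something is new, unique, unknown or untested is made for them only; others in the source may bear on it.

For the measured compounds named here, compound 3 `CCCNC(=O)c1cc(Oc2ccc(NC(=O)c3cc4cccnc4n(-c4ccccc4)c3=O)cc2)ccn1` holds the lower of the two numbers so far available in a functional assay on NCI-H460 cells (Homo sapiens) for antiproliferative activity, read by MTT assay, with a stated time of 72 h; on this read-out higher numbers stand for weaker inhibition and lower numbers for stronger inhibition: compound 3 gives 110 nM, while compound 1 `CNC(=O)c1cc(Oc2ccc(NC(=O)c3cc4cccnc4n(-c4ccccc4)c3=O)cc2)ccn1` gives 320 nM. Going by the values given here, the single measured step, a 2.9-fold lower number from compound 1 to compound 3 (0.46 log units; beyond the scatter), separates these two. A third member of the series, compound 2 `CNC(=O)c1cc(Oc2ccc(NC(=O)c3cc4cccnc4n(-c4ccc(OC)cc4)c3=O)cc2)ccn1`, has no reported result in this assay: for compound 2 the entry reads "not determined" (no result reported). Compound 4 `CCCNC(=O)c1cc(Oc2ccc(NC(=O)c3cc4cccnc4n(-c4ccc(OC)cc4)c3=O)cc2)ccn1` differs from compound 3 by methoxy in place of hydrogen on an aromatic carbon. Among the compounds with values here, no measured step bears directly on this change, since the one compound that carries the same group, compound 2, lacks a number, and the step from compound 1 to compound 3 concerns a different part of the molecule. With no comparison available, for compound 4 the expected step of no change at the digits printed from compound 3 to compound 4 (within the scatter) is accordingly none beyond the scatter. Compound 4 is therefore estimated at 110 nM in this assay, with a range from 45 nM to 270 nM.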

Compound 4, half-maximal inhibitory concentration: 1730 nM
Compound 4: the middle estimate sits 16-fold (1.20 log units) below what was measured; the measured number lies above the stated range.
By their numbers in this assay, from the lowest: compound 3; then compound 1; then compound 4.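

Methoxy in place of hydrogen on an aromatic carbon, para to a large group, gives a 16-fold higher number from compound 3 to compound 4 (1.20 log units; beyond the scatter) in this assay and so provides the first reading of any change at this position. This step is larger than the only earlier one, a 2.9-fold lower number from compound 1 to compound 3 (0.46 log units; beyond the scatter) and runs the opposite way, showing that this aromatic position responds strongly to the phenyl to 4-methoxyphenyl change. No available measurement accounts for the size of this step.

The compounds shown leave open whether the higher number is particular to methoxy or would also arise with fluorine, hydroxyl or methyl on the same carbon. They also leave open whether a longer chain than propyl on the amide would alter the size of this step.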